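The compounds below may be only part of what the source reports. "The series", "measured", "known", "first", "only" and "open" are said of these compounds alone.

Measured so far in an assay on U2OS cells for inhibition of secreted frizzled-related protein 1 (Homo sapiens), read by a luciferase reporter, with a stated time of 18 h; on this read-out lower numbers stand for an effect already at smaller amounts and higher numbers for an effect only at larger amounts of compound: compound 1 `O=C(c1cccc(Cl)c1)N1CCC(NS(=O)(=O)c2cc(S(=O)(=O)c3ccccc3)ccc2C(F)(F)F)CC1` gives 870 nM; compound 2 `O=C(c1ccc(C(F)(F)F)cc1)N1CCC(NS(=O)(=O)c2cc(S(=O)(=O)c3ccccc3)ccc2C(F)(F)F)CC1` gives 970 nM; compound 3 `N#Cc1cccc(S(=O)(=O)N2CCC(NS(=O)(=O)c3cc(S(=O)(=O)c4ccccc4)ccc3C(F)(F)F)CC2)c1` gives 170 nM.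

Compound 3 stands at the lowest number of the three, with a 5.1-fold lower number from compound 1 to compound 3 (0.71 log units; beyond the scatter) and a 5.7-fold lower number from compound 2 to compound 3 (0.76 log units; beyond the scatter) both beyond the scatter, whereas a 1.1-fold higher number from compound 1 to compound 2 (0.05 log units; within the scatter) lies within it. Compound 4 `O=C(O)c1ccc(N2CCC(NS(=O)(=O)c3cc(S(=O)(=O)c4ccccc4)ccc3C(F)(F)F)CC2)cc1` carries the change (4-carboxyphenyl in place of (3-cyanophenyl)sulfonyl on an amine nitrogen in a ring). Going by the values given here, no measured step covers this change directly: the two steps into compound 3 swap a carbonyl-linked aryl for a sulfonyl-linked aryl on the same ring nitrogen, and only show that the group there moves the number well beyond the scatter. Compound 4 drops the sulfonyl linker and the nitrile altogether, so the expected step of an 8.8-fold higher number from compound 3 to compound 4 (0.95 log units; beyond the scatter) is toward a higher number, with wide uncertainty. Compound 4 is estimated at 1500 nM, range 300 nM to 8000 nM.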

Compound 4, half-maximal effective concentration: 230 nM
Estimate against measurement, compound 4: 6.5-fold (0.81 log units) above; measured number below the stated range.
By their numbers in this assay, from the lowest: compounds 3 and 4 (each within the scatter of the next); then compounds 1 and 2 (each within the scatter of the next).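

In this assay, 4-carboxyphenyl on the amine nitrogen in the ring, with no sulfonyl or carbonyl linking it, gives a 1.4-fold higher number from compound 3 to compound 4 (0.13 log units; within the scatter), so among these compounds a sulfonyl link at this position is not needed to reach this range. The carbonyl-linked aryl groups fall short of it, with a 4.2-fold lower number from compound 2 to compound 4 (0.63 log units; beyond the scatter) and a 3.8-fold lower number from compound 1 to compound 4 (0.58 log units; beyond the scatter). No data here explain these steps.

Still open, going by these compounds, is whether a methyl ester or a primary amide in place of the carboxylic acid keeps the number in this range. Also open, on these data alone, is how a carboxylic acid on the sulfonyl-linked aryl would read.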